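The compounds below may be only part of what the source reports. "The series", "measured", "known", "first", "only" and "open" are said of these compounds alone.

Compound 1 `O=C(CCCCC1CCSS1)Nc1ccccc1Cl`: 14.6%
Compound 2 `O=C(CCCCC1CCSS1)Nc1ccccn1`: "not active" (no number reported)
Compound 3 `O=C(CCCCC1CCSS1)Nc1ccc(Cl)cn1`: 33.7%

These three compounds were tested in a functional assay on NCI-H460 cells (Homo sapiens) for inhibition, read by MTT assay, with a stated time of 24 h, tested at 10 ug/mL; a lower number here means less inhibition of growth, a higher number more inhibition of growth at the concentration tested. Compound 3 gives 33.7%, the higher of the two numbers available, and compound 1 gives 14.6%, a gap beyond the usual scatter. Compound 2 has no number and was reported only as "not active" (no number reported).

The next compound to be tested is compound 4 `O=C(CCCCC1CCSS1)Nc1ccc(Br)cn1`, which has bromo in place of chloro on an aromatic carbon, para to a large group: bromo in place of chloro on an aromatic carbon. Among the compounds with values here, no measured pair of compounds here shows what such a swap does, so the expectation has to start from compound 3 at 33.7%. With one halogen exchanged for another, no shift beyond the scatter is expected in either direction in this assay. The expected change is small, a number 1.3 percentage points higher from compound 3 to compound 4 (within the scatter). For compound 4 the estimated value is 35%, with a range from 20% to 50%.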

Compound 4, percent growth inhibition at one concentration: 38%
Beside the measured number, compound 4's estimate is 3 percentage points below it, and the stated range covers the measured number.
By their numbers in this assay, from the lowest: compound 1; then compounds 3 and 4 (each within the scatter of the next).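

Bromo in place of chloro on this aromatic carbon, para to a large group and two atoms from the ring nitrogen, gives a number 4.3 percentage points higher from compound 3 to compound 4 (within the scatter) in this assay and is the first step here that changes only this substituent. Within this one pair, the carbon takes either halogen with no difference that can be told from the scatter, so the two compounds read alike at the single concentration tested. No measurement here explains why the two halogens give such similar readings.

As far as these compounds go, whether the reading would hold with something other than a halogen at this carbon, such as an amine, a methoxy group or a carboxylic acid, stays open. So does what iodo would do there, and whether bromo would read the same on another carbon of the ring.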